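A few compounds are considered here, and "the series" means these few. Any claim that something is new, unique, unknown or untested is made for them only; others in the source may bear on it.

Measured so far, in a functional assay on DU-145 cells (Homo sapiens) for antiproliferative activity, read by propidium iodide staining, with a stated time of 96 h; on this read-out lower numbers stand for stronger inhibition and higher numbers for weaker inhibition:

Compound 1, `CC(O)(CSc1cc(C(F)(F)F)cc(C(F)(F)F)c1)C(=O)Nc1cccc(S(F)(F)(F)(F)F)c1`: compound 1 gives 9400 nM.
Compound 2, `CC(O)(COc1ccc(S(F)(F)(F)(F)F)cc1)C(=O)Nc1cc(C(F)(F)F)cc(C(F)(F)F)c1`: compound 2 gives 6500 nM.
Compound 3, `CC(O)(COc1ccc(C(F)(F)C(F)(F)F)cc1)C(=O)Nc1cc(C(F)(F)F)cc(C(F)(F)F)c1`: compound 3 gives 6800 nM.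

These three numbers all lie within the usual scatter of one another, so none of the three compounds can be called stronger or weaker than the others on this read-out.

Compound 4, `CC(O)(CSc1cc(C(F)(F)F)cc(C(F)(F)F)c1)C(=O)Nc1cccc(C(F)(F)C(F)(F)F)c1`, has not yet been tested. It differs from compound 1 in one place: a group of 7 heavy atoms (2 carbon, 5 fluorine; no ring) in place of a group of 6 heavy atoms (5 fluorine, 1 sulfur; no ring), on an aromatic carbon. A change of the same kind has already been made once among the measured compounds, from compound 2 to compound 3: a group of 7 heavy atoms (2 carbon, 5 fluorine; no ring) in place of a group of 6 heavy atoms (5 fluorine, 1 sulfur; no ring), on an aromatic carbon. That step gave a 1.0-fold higher number from compound 2 to compound 3 (0.02 log units; within the scatter). The two places are not the same word for word: in compound 2 the group that leaves sits para to a large group, while in compound 1 it sits meta to a large group, so the two changes are of the same kind rather than the same change. The cores of compound 1 and compound 2 also differ, and that difference is not broken down here.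

Because the earlier step came out as a 1.0-fold higher number from compound 2 to compound 3 (0.02 log units; within the scatter), the step from compound 1 to compound 4 in this assay is expected to be a 1.0-fold higher number from compound 1 to compound 4 (0.00 log units; within the scatter). Compound 4 is therefore estimated at 9500 nM, with the number expected to fall between 4500 nM and 20000 nM.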

Compound 4, half-maximal inhibitory concentration: 8900 nM
For compound 4 the middle estimate is 1.1-fold (0.03 log units) above the measured one; the range from low to high includes it.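

In this assay, putting 1,1,2,2,2-pentafluoroethyl in place of the group of 6 heavy atoms (5 fluorine, 1 sulfur) gives a 1.1-fold lower number from compound 1 to compound 4 (0.02 log units; within the scatter). The same change has now been read on two cores, and the two results agree: the same change on two cores in this assay, a 1.0-fold higher number (0.02 log units; within the scatter) from compound 2 to compound 3 and a 1.1-fold lower number (0.02 log units; within the scatter) from compound 1 to compound 4, 1.1-fold (0.04 log units) apart, within the scatter of two such steps On these two pairs, then, the two groups can stand in for each other without any readable difference on this read-out, but that is all the result shows: two pairs are a small sample, and a step too small to read on both cores says nothing about whether a large effect would carry from one core to another, or whether this change would stay silent on a third core.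

The compounds shown leave open whether a group of a different kind at this place on the ring, such as an amine, a carboxylic acid or a nitrile, would move the number beyond the usual scatter. They also leave open whether any change at this place can bring the number well below the narrow range that all four compounds share.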